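Aryl swap on the amine of compound 2

A few compounds are considered here, and "the series" means these few. Any claim that something is new, unique, unknown or untested is made for them only; others in the source may bear on it.

For the measured compounds named here, compound 2 `Fc1ccc(Nc2nc3nonc3nc2Nc2ccccc2F)c(F)c1` gives the only number in an assay on mitochondria from L6 cells (Rattus norvegicus) for activation, with a stated time of 90 min (a higher number here means that more compound is needed for the effect, a lower number that less compound is needed), namely 300 nM. Compound 1 `Fc1ccccc1Nc1nc2nonc2nc1NCCC(F)(F)F` reaches only a limit, > 100000 nM, a limit also noted as the limit of > 100000 nM in this assay, at which 1 of the 2 values shown sits. Between them stands an at least 330-fold lower number from compound 1 to compound 2 (2.52 log units; beyond the scatter). Compound 3 `Cc1cccc(Nc2nc3nonc3nc2Nc2ccccc2F)c1` differs from compound 2 by 3-methylphenyl in place of 2,4-difluorophenyl on a nitrogen on an aromatic ring. Going by the values given here, the single measured step concerns replacing a fluorinated chain with an aryl ring, not one aryl ring with another, so no change beyond the scatter is expected in this assay; the expected step is a 1.3-fold higher number from compound 2 to compound 3 (0.12 log units; within the scatter). Compound 3 is therefore estimated at 400 nM, within a range from 100 nM to 2000 nM.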

Compound 3, half-maximal effective concentration: 1500 nM
Beside the measured number, compound 3's estimate is 3.8-fold (0.57 log units) below it; the measured number falls inside the stated range.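

In this assay, one aryl ring cannot simply stand in for another on this nitrogen: 3-methylphenyl in place of 2,4-difluorophenyl gives a 5.0-fold higher number from compound 2 to compound 3 (0.70 log units; beyond the scatter). The gain from an aryl ring over the 3,3,3-trifluoropropyl chain is not confined to 2,4-difluorophenyl, with an at least 66-fold lower number from compound 1 to compound 3 (1.82 log units; beyond the scatter). Compound 1 enters that comparison as a limit, not a number: the limit of > 100000 nM in this assay, at which 1 of the 3 values shown sits.

Fluorine and methyl differ together here, so the effects of the substituents and of their places on the ring remain unseparated. Going by these compounds, how an unsubstituted phenyl or a pyridine ring on this nitrogen would read remains open.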